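Sulfamoyl for trifluoromethylsulfonyl on the amide side chain

This account rests on a few compounds, and the source may have more. Where it says the series, first, only, none or still open, it means among the compounds named here.

The series shares the core of compound 1 `CC[C@H]1CN(c2nc(N)c(C(=O)NC)nc2Cl)CCN1C1CCN(Cc2ccc(Cl)cc2)CC1`, which in an in vitro assay on BaF3 cells for displacement of a labelled ligand from C-X-C chemokine receptor type 3 (Homo sapiens) (on this read-out higher numbers stand for weaker inhibition and lower numbers for stronger inhibition), gives 0.3 nM. Compound 2 `CC[C@H]1CN(c2nc(N)c(C(=O)NCCNS(=O)(=O)C(F)(F)F)nc2Cl)CCN1C1CCN(Cc2ccc(Cl)cc2)CC1` carries the extended amide side chain and in this assay gives 0.9 nM, the higher of the measured pair; the step of a 3.0-fold higher number from compound 1 to compound 2 (0.48 log units; beyond the scatter) is the only one recorded. Compound 3 `CC[C@H]1CN(c2nc(N)c(C(=O)NCCNS(N)(=O)=O)nc2Cl)CCN1C1CCN(Cc2ccc(Cl)cc2)CC1` differs from compound 2 by amino in place of trifluoromethyl on a sulfonyl sulfur. Among the measured compounds shown here, the recorded step concerns adding the whole side chain, not the group on its sulfonyl sulfur, so no measured step bears directly on this exchange; the side chain itself cost only a modest amount in this assay. Compound 3 is therefore expected to stay close to compound 2, with a step of a 1.1-fold higher number from compound 2 to compound 3 (0.05 log units; within the scatter) not beyond the scatter. The estimate for compound 3 in this assay is 1 nM, within a range from 0.4 nM to 2.5 nM.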

Compound 3, half-maximal inhibitory concentration: 1.9 nM
Estimate against measurement, compound 3: 1.9-fold (0.28 log units) below; measured number inside the range.
By their numbers in this assay, from the lowest: compound 1; then compound 2; then compound 3.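

In this assay the group on the sulfonyl sulfur matters to the reading: amino in place of trifluoromethyl gives a 2.1-fold higher number from compound 2 to compound 3 (0.32 log units; beyond the scatter), a step beyond the scatter that the earlier pair could not show, since that pair concerned only the whole side chain. Against the plain methyl amide, the side chain ending in sulfamoylamino gives a 6.3-fold higher number from compound 1 to compound 3 (0.80 log units; beyond the scatter), compared with a 3.0-fold higher number from compound 1 to compound 2 (0.48 log units; beyond the scatter) for the trifluoromethyl version, so the cost of extending the amide depends on what the sulfonyl sulfur carries. No supporting measurement accompanies these numbers to account for the change.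

A single exchange leaves open how a methyl or a phenyl on the same sulfonyl sulfur would read. Also open, on these data alone, is whether a longer chain between the amide nitrogen and the sulfonamide nitrogen would change the step.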